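Shortening the Chain: Pentyl to Butyl on the Shared Core

The source may hold more compounds than are shown below. What is called first, only, known or untested is meant among the compounds shown, and "the series" means these compounds.

Compound 1 `O=C1C2=C(C(=O)c3ncccc31)C1(CS2)NC(=O)N(c2ccc([N+](=O)[O-])cc2)C1=O` gives 1030 nM in a functional assay on XF498 cells (Homo sapiens) for antiproliferative activity, read by MTT assay, with a stated time of 96 h; a lower number here means a stronger inhibitor, a higher number a weaker inhibitor.
Compound 2 `CCc1ccc(N2C(=O)NC3(CSC4=C3C(=O)c3ncccc3C4=O)C2=O)cc1` gives 1200 nM.
Compound 3 `CCCCCc1ccc(N2C(=O)NC3(CSC4=C3C(=O)c3ncccc3C4=O)C2=O)cc1` gives 830 nM.

Within the data shown here, compound 3 shows the lowest of the three numbers, yet the steps of a 1.2-fold lower number from compound 1 to compound 3 (0.09 log units; within the scatter) and a 1.4-fold lower number from compound 2 to compound 3 (0.16 log units; within the scatter) both stay within the usual scatter, so no compound can be called stronger than another here. Compound 4 `CCCCc1ccc(N2C(=O)NC3(CSC4=C3C(=O)c3ncccc3C4=O)C2=O)cc1` differs from compound 3 in one place: hydrogen in place of methyl on a saturated chain carbon, four bonds along the chain from an aromatic carbon. Among the measured compounds shown here, the only measured step that bears on this is a 1.4-fold lower number from compound 2 to compound 3 (0.16 log units; within the scatter), where the chain grew and the number barely moved. The shorter chain of compound 4 is therefore expected to give nothing beyond the scatter, a step of about a 1.1-fold higher number from compound 3 to compound 4 (0.06 log units; within the scatter). Compound 4 is estimated at 950 nM, with a range from 500 nM to 1800 nM.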

Compound 4, half-maximal inhibitory concentration: 950 nM
Compound 4: middle estimate and measured number agree at the digits printed, within the range that was stated.
By their numbers in this assay, from the lowest: compounds 3, 4, 1 and 2 (each within the scatter of the next).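

Taking one carbon off the pentyl chain leaves the number in this assay within the scatter (a 1.1-fold higher number from compound 3 to compound 4 (0.06 log units; within the scatter)). The butyl chain of compound 4 also stays within the scatter when it replaces a shorter chain or the nitro group (a 1.3-fold lower number from compound 2 to compound 4 (0.10 log units; within the scatter); a 1.1-fold lower number from compound 1 to compound 4 (0.04 log units; within the scatter)), so among ethyl, butyl and pentyl no effect of chain length can be read. No supporting measurement bears on this result.

Still open, going by these compounds, is whether an amine, a carboxylic acid or a chain longer than pentyl in this place would move the number beyond the scatter.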